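A few compounds are considered here, and "the series" means these few. Any claim that something is new, unique, unknown or untested is made for them only; others in the source may bear on it.

Measured so far in a functional assay on HL-60 cells (Homo sapiens) for inhibition, read by MTT assay, with a stated time of 72 h; a lower number here means a stronger inhibitor, a higher number a weaker inhibitor:
compound 1 `CC(=O)Nc1cccc(-c2nc(C)oc2C(=O)N2CCN(c3cccc(Cl)c3)CC2)c1`: 208 nM
compound 2 `Cc1nc(-c2ccccc2Cl)c(C(=O)N2CCN(c3cccc(Cl)c3)CC2)o1`: 132 nM

For the measured compounds named here, compound 2 has only one measured neighbour, and the two values lie within the scatter of each other: a 1.6-fold lower number from compound 1 to compound 2 (0.20 log units; within the scatter). Next is compound 3 `COc1cccc(-c2nc(C)oc2C(=O)N2CCN(c3cccc(Cl)c3)CC2)c1`, with 3-methoxyphenyl in place of 2-chlorophenyl on an aromatic carbon. Going by the values given here, the only measured step bearing on this place is that same one, from 3-acetamidophenyl to 2-chlorophenyl, and it stayed within the scatter. No step beyond the scatter is therefore expected in this assay, and one step gives little support. The expected change is a 1.3-fold higher number from compound 2 to compound 3 (0.11 log units; within the scatter). Compound 3 is estimated at 170 nM, with an expected range of 70 nM to 420 nM.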

Compound 3, half-maximal inhibitory concentration: "not active" (no number reported)
Compound 3: no number reported, and the estimate cannot be compared.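

For the compounds shown here, compound 3 is reported as "not active" without a number, and no step from compound 2 to compound 3 can be read. No evidence at hand bears on this result.

The compounds shown leave open how 3-methoxyphenyl compares with 3-acetamidophenyl and 2-chlorophenyl on the shared core.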